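The compounds below may be only part of what the source reports. "The series", "measured", "known", "first", "only" and "open" are said of these compounds alone.

Measured so far:

Compound 1, `COc1ccc(Nc2n[n+]([O-])c3ccccc3[n+]2[O-])cc1` — 2900 nM
Compound 2, `[O-][n+]1nc(NC2CCCCC2)[n+]([O-])c2ccccc21` — 2600 nM

In a functional assay on K562 cells (Homo sapiens) for cytotoxicity, read by MTT assay, with a stated time of 48 h (on this read-out higher numbers stand for weaker inhibition and lower numbers for stronger inhibition), compound 1 gives 2900 nM, and in the same assay compound 2 gives 2600 nM. Compound 2 carries the lowest of the two numbers recorded, but its nearest neighbour is compound 1, whose number sits only slightly higher, within the scatter of this assay, so the two compounds cannot be placed in any order. Among the compounds with values here, no step between measured compounds is known here.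

Compound 3, `C=CCNc1n[n+]([O-])c2ccccc2[n+]1[O-]`, has not yet been measured. Its change from compound 2 is counted as allyl in place of cyclohexyl on a nitrogen on an aromatic ring. Within the data shown here, with no measured step to lean on, the account expects a small step in this assay, if any, tilting toward a weaker number, and it is not expected to go clearly beyond the scatter. The estimated step from compound 2 to compound 3 is a 1.5-fold higher number from compound 2 to compound 3 (0.19 log units; within the scatter). Compound 3 is expected to give about 4000 nM, with a range from 1500 nM to 11000 nM.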

Compound 3, half-maximal inhibitory concentration: 11200 nM
Estimate against measurement, compound 3: 2.8-fold (0.45 log units) below; measured number outside the range, above it.
By their numbers in this assay, from the lowest: compounds 2 and 1 (each within the scatter of the next); then compound 3.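

In this assay allyl in place of cyclohexyl on a nitrogen on an aromatic ring gives a 4.3-fold higher number from compound 2 to compound 3 (0.63 log units; beyond the scatter) and so shows that this position responds to what it carries, which compounds 1 and 2, within the scatter of each other, could not show. The change takes away a six-membered non-aromatic ring of carbon only and brings an open group with a double bond outside aromatic rings, and this single step cannot tell these differences apart. Nothing measured here explains the step.

From the compounds shown here alone, it remains open whether the loss of the ring or the double bond goes with the higher number, which a saturated propyl group on the same nitrogen could help to separate. Going by these compounds, how a longer chain, or a chain ending in an amine, would behave at this position also stays open.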